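A few compounds are considered here, and "the series" means these few. Any claim that something is new, unique, unknown or untested is made for them only; others in the source may bear on it.

Working notes on the series.

For the measured compounds named here, compound 1, `N#Cc1ccn2c(-c3ccccc3)c(-c3ccccc3)c(Cc3ccccc3)c2c1`, is the only member of the series with a number so far. Going by the values given here, in an assay for inhibition of Polyunsaturated fatty acid lipoxygenase ALOX15 (Oryctolagus cuniculus) (a lower number here means a stronger inhibitor, a higher number a weaker inhibitor), compound 1 gives 46000 nM, which places it as a weak inhibitor on the single value available; there is nothing else in the set to rank it against. Compound 2, `N#Cc1ccn2c(-c3ccccc3)c(-c3ccccc3)c(OCc3ccc(F)cc3)c2c1`, carries no result in this assay, its entry reading "not determined" (no result reported). Compound 3, `Cc1c(-c2ccccc2)c(-c2ccccc2)n2ccc(C#N)cc12`, likewise shows only "not determined" (no result reported) in this assay. Among the compounds with values here, no step between two measured compounds exists, so nothing tells how a change at this position moves the read-out.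

Compound 4, `N#Cc1ccn2c(-c3ccccc3)c(-c3ccccc3)c(C=O)c2c1`, is the next compound to be measured in this assay. Its structure differs from that of compound 1 in one place: formyl in place of benzyl on an aromatic carbon. The benzyl group that leaves is large and the formyl group that enters is small and brings one hydrogen-bond acceptor; the remainder of the shared core is unchanged.

Within the data shown here, with no measured step to lean on, the expectation for this assay is a move from compound 1 that is modest at most, with no firm direction, and quite possibly nothing beyond the scatter. The step expected is a 1.3-fold higher number from compound 1 to compound 4 (0.12 log units; within the scatter). Compound 4 is thus estimated at 60000 nM, within a range from 15000 nM to 250000 nM, pending the measurement.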

Compound 4, half-maximal inhibitory concentration: 61000 nM
Compound 4: middle estimate off by 1.0-fold (0.01 log units), on the low side, within the range that was stated.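

In this assay, for the compounds shown here, the first measured step at this position reads a 1.3-fold higher number from compound 1 to compound 4 (0.12 log units; within the scatter), so on this aromatic carbon, two ring bonds from the ring nitrogen, formyl in place of benzyl gives no difference that can be told from the scatter. The series now shows that a group with a six-membered aromatic ring and a far smaller one with a hydrogen-bond acceptor can stand on this carbon with the two values still level: compound 1 gives 46000 nM and compound 4 gives 61000 nM, both weak on these numbers. Nothing available bears on why these two values lie so close.

Going by these compounds, whether any group on this carbon can move the number beyond the scatter stays open, for instance a carboxylic acid, an aminomethyl group or a longer chain such as phenethyl. Steps involving compound 2 and compound 3 cannot be read, and the two phenyl groups and the nitrile are the same in every compound shown, so what they contribute remains unknown.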